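The source may hold more compounds than are shown below. What is called first, only, known or untested is meant among the compounds shown, and "the series" means these compounds.

Compound 1, `S=C(Nc1ccccc1)N1N=C(c2ccccc2)CC1c1ccc2c(c1)OCCO2`: 3180 nM
Compound 2, `S=C(Nc1ccccc1)N1N=C(c2ccc(Cl)cc2)CC1c1ccc2c(c1)OCCO2`: > 200000 nM (a limit, not a number)
Compound 3, `Cc1ccc(C2=NN(C(=S)Nc3ccccc3)C(c3ccc4c(c3)OCCO4)C2)cc1`: 10300 nM

The three measured compounds share one core and differ only in the group on the six-membered aromatic ring of carbon only, para to a large group. In a functional assay on WM 266-4 cells (Homo sapiens) for antiproliferative activity, read by MTT assay, with a stated time of 48 h (a lower number here means a stronger inhibitor of growth, a higher number a weaker inhibitor of growth), compound 3 gives 10300 nM, the highest of the two numbers; the nearest number is that of compound 1, 3180 nM. Compound 2 reaches only a limit, > 200000 nM, at the limit of > 200000 nM in this assay, at which 1 of the 3 values shown sits.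

The measured steps all concern this one position. A methyl entering there brought a 3.2-fold higher number from compound 1 to compound 3 (0.51 log units; beyond the scatter); a chloro entering there brought an at least 62-fold higher number from compound 1 to compound 2 (1.79 log units; beyond the scatter); and from the chloro to the methyl the number moved by an at least 19-fold lower number from compound 2 to compound 3 (1.28 log units; beyond the scatter).

Compound 4, `O=[N+]([O-])c1ccc(C2=NN(C(=S)Nc3ccccc3)C(c3ccc4c(c3)OCCO4)C2)cc1`, is the next member: nitro in place of methyl on an aromatic carbon. Both substituents so far tried at this position raised the number, the methyl modestly and the chloro greatly. The nitro is therefore expected to raise it as well, and compound 4 is estimated to show a 4.9-fold higher number from compound 3 to compound 4 (0.69 log units; beyond the scatter), with a real chance that this assay returns only a limit. For compound 4 the estimate is 50000 nM, in the range 10000 nM to 200000 nM.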

Compound 4, concentration for 50% growth inhibition: 105000 nM
Estimate against measurement, compound 4: 2.1-fold (0.32 log units) below; the measured number falls inside the stated range.
By their numbers in this assay, from the lowest: compound 1; then compound 3; then compound 4. At a limit, above all of these: compound 2.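

In this assay, nitro is now the third group placed on this aromatic carbon, para to a large group, and it also falls on the weaker side of the unsubstituted compound, with a 33-fold higher number from compound 1 to compound 4 (1.52 log units; beyond the scatter), so among the compounds shown hydrogen still gives the lowest number. Going from 4-methylphenyl to 4-nitrophenyl brought a 10-fold higher number from compound 3 to compound 4 (1.01 log units; beyond the scatter), which makes this the first large rise at this position that ends on a real number rather than a limit, and it shows that the size of the change depends strongly on which group enters. Compound 2 stands at a limit, so its step to the nitro is only a floor, an at least 1.9-fold lower number from compound 2 to compound 4 (0.27 log units; that floor lies within the scatter), and it does not put chloro and nitro in order: the limit of > 200000 nM in this assay, at which 1 of the 4 values shown sits.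

The compounds shown leave open whether any group at this position, such as an amine, a hydroxyl or a fluoro, could bring the number below that of compound 1. They also leave open whether a longer chain, or a carboxylic acid, would follow the modest step seen with methyl or the large ones seen with chloro and nitro.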